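Pyrazole isomers on the shared core

The compounds below may be only part of what the source reports. "The series", "measured", "known", "first", "only" and "open" are said of these compounds alone.

Compound 3 `Cc1n[nH]cc1-c1cccc2c1CCC2c1ncc[nH]1` gives 3 nM in a functional assay on CHO cells for agonist activity at Alpha-1A adrenergic receptor (Homo sapiens), read by FLIPR and calcium flux (on this read-out lower numbers stand for an effect already at smaller amounts and higher numbers for an effect only at larger amounts of compound), the lowest number among the measured compounds. Compound 1 `CCCS(=O)(=O)Nc1cccc2c1CCC2c1ncc[nH]1` gives 1340 nM in this assay. Compound 2 `Cn1cc(-c2cccc3c2CCC3c2ncc[nH]2)cn1` reaches only the limit > 2900 nM in this assay. Compound 4 `Cn1nccc1-c1cccc2c1CCC2c1ncc[nH]1` is not yet measured; (1-methyl-1H-pyrazol-5-yl in place of 3-methyl-1H-pyrazol-4-yl on an aromatic carbon). For the measured compounds named here, the steps that bear on this change are an at least 960-fold lower number from compound 2 to compound 3 (2.98 log units; beyond the scatter) and a 450-fold lower number from compound 1 to compound 3 (2.65 log units; beyond the scatter); the first is the closer match, since both compound 2 and compound 4 carry the methyl on a ring nitrogen. A large rise is therefore expected, a 330-fold higher number from compound 3 to compound 4 (2.52 log units; beyond the scatter). The size is uncertain because compound 2 sits at the limit of > 2900 nM in this assay, at which 1 of the 3 values shown sits. Compound 4 is estimated at 1000 nM, within 100 nM to 5000 nM.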

Compound 4, half-maximal effective concentration: 278 nM
Beside the measured number, compound 4's estimate is 3.6-fold (0.56 log units) above it, and the stated range covers the measured number.
By their numbers in this assay, from the lowest: compound 3; then compound 4; then compound 1. At a limit, above all of these: compound 2.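

Exchanging the 3-methyl-1H-pyrazol-4-yl for its isomer 1-methyl-1H-pyrazol-5-yl, with the same atoms but 0 hydrogen-bond donors, carries a large cost at this position: a 93-fold higher number from compound 3 to compound 4 (1.97 log units; beyond the scatter). The two isomers with the methyl on a ring nitrogen also differ, although this step starts from a limit of the assay and reads only as a bound: an at least 10-fold lower number from compound 2 to compound 4 (1.01 log units; beyond the scatter). The 1-methyl-1H-pyrazol-5-yl still stands modestly ahead of the (propylsulfonyl)amino group: a 4.8-fold lower number from compound 1 to compound 4 (0.68 log units; beyond the scatter).

On these data alone, what a plain 1H-pyrazol-4-yl or a 3-amino-1H-pyrazol-4-yl would give at this position stays open. As far as these compounds go, it is also open whether the ring-nitrogen hydrogen or the placement of the methyl carries the low number of compound 3.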